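Isopropyl to Ethoxy: Expected Effect on Cytotoxicity

This account rests on a few compounds, and the source may have more. Where it says the series, first, only, none or still open, it means among the compounds named here.

Measured so far in a toxicity assay on MT2 cells (Homo sapiens) for cytotoxicity, read by MTT assay; on this read-out higher numbers stand for lower toxicity in this test and lower numbers for higher toxicity in this test:
Compound 1, `Cc1c(Oc2ccccc2OCCn2ccc(=O)[nH]c2=O)cc(F)c2ccc(C#N)cc12`, gives > 100000 nM, which is a limit of the assay rather than a number.
Compound 2, `CCc1cc(Oc2ccccc2OCCn2ccc(=O)[nH]c2=O)c(C)c2cc(C#N)ccc12`, gives 12000 nM.
Compound 3, `Cc1c(Oc2ccccc2OCCn2ccc(=O)[nH]c2=O)cc(C(C)C)c2ccc(C#N)cc12`, gives 9000 nM.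

Compound 3 holds the lowest of the two numbers in this assay, but its nearest neighbour, compound 2, lies within the scatter: a 1.3-fold lower number from compound 2 to compound 3 (0.12 log units; within the scatter). The two therefore cannot be told apart. Both sit well away from the limit shown by compound 1, as an at least 8.3-fold lower number from compound 1 to compound 2 (0.92 log units; beyond the scatter) and an at least 11-fold lower number from compound 1 to compound 3 (1.04 log units; beyond the scatter) show. In those two steps, an alkyl group replaced fluoro on an aromatic carbon and the number fell clearly; adding a methyl to that alkyl chain, from compound 2 to compound 3, changed nothing beyond the scatter.

Compound 4, `CCOc1cc(Oc2ccccc2OCCn2ccc(=O)[nH]c2=O)c(C)c2cc(C#N)ccc12`, has not yet been measured. It differs from compound 3 in one place: ethoxy in place of isopropyl on an aromatic carbon. Going by the values given here, no measured step swaps an alkyl for an alkoxy group, so no direct guide exists; the earlier steps only show that the ethyl and isopropyl compounds resemble each other and differ from the fluoro compound. Compound 4 is expected to give 20000 nM, with a range from 6000 nM to 80000 nM. The expected step is a 2.2-fold higher number from compound 3 to compound 4 (0.35 log units; beyond the scatter), a modest rise that is uncertain in direction.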

Compound 4, half-maximal cytotoxic concentration: > 100000 nM
Compound 4: no number, only a limit; the forecaster's own chance of this, stated with the estimate: 25%; middle value at least 5.0-fold (0.69 log units) from the limit.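

In this assay, isopropyl and ethoxy each have 3 heavy atoms, yet this change gives an at least 11-fold higher number from compound 3 to compound 4 (1.04 log units; beyond the scatter), and ethoxy in place of ethyl gives an at least 8.3-fold higher number from compound 2 to compound 4 (0.92 log units; beyond the scatter). The number at this position therefore does not follow the count of heavy atoms alone: the ethoxy group, which carries an oxygen and 1 hydrogen-bond acceptor, puts compound 4 with the fluoro compound 1 and apart from the alkyl compounds 2 and 3, so the earlier contrast was not simply fluoro against anything larger. The step between compound 1 and compound 4 cannot be read, since each of them gives only a limit of the assay and not a number: the limit of > 100000 nM in this assay, at which 2 of the 4 values shown sit.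

The compounds shown leave open whether the oxygen itself goes with the higher number or whether this holds only for ethoxy as a whole, a question that a methoxy group or a longer alkoxy chain on the same aromatic carbon would help to settle. They also leave open whether a hydroxyl or an amine at this position would fall with ethoxy or with the alkyl groups.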